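Pyrrolidine in place of methylpiperazine at the benzylic carbon

The source may hold more compounds than are shown below. What is called first, only, known or untested is meant among the compounds shown, and "the series" means these compounds.

Measured so far in a functional assay on A-431 cells (Homo sapiens) for antiproliferative activity, read by MTT assay, with a stated time of 72 h; a higher number here means a weaker inhibitor, a lower number a stronger inhibitor:
- compound 1, `CN1CCN(Cc2ccc(NC(=O)Nc3ccc4ncnc(Nc5ccc(F)c(Cl)c5)c4c3)cc2)CC1`, gives 4000 nM.
- compound 2, `CN1CCN(Cc2ccc(NC(=O)Nc3ccc4ncnc(Nc5ccc(F)c(F)c5)c4c3)cc2)CC1`, gives only a limit of the assay, > 10000 nM.
- compound 3, `CN1CCN(Cc2ccc(NC(=O)Nc3ccc4ncnc(Nc5cccc(C(F)(F)F)c5)c4c3)cc2)CC1`, gives 2410 nM.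

Compound 3 holds the lowest of the two numbers shown in this assay. Its nearest neighbour is compound 1: the step of a 1.7-fold lower number from compound 1 to compound 3 (0.22 log units; within the scatter) lies within the scatter, so the two cannot be ordered. The step of an at least 4.1-fold lower number from compound 2 to compound 3 (0.61 log units; beyond the scatter) is at least modest, but rests on a limit (the limit of > 10000 nM in this assay, at which 1 of the 3 values shown sits). The step of an at least 2.5-fold higher number from compound 1 to compound 2 (0.39 log units; beyond the scatter) is also at least modest and rests on the same limit.

Compound 4, `O=C(Nc1ccc(CN2CCCC2)cc1)Nc1ccc2ncnc(Nc3cccc(C(F)(F)F)c3)c2c1`, differs from compound 3 at a different place: pyrrolidin-1-yl in place of 4-methylpiperazin-1-yl on a saturated chain carbon bound to an aromatic carbon. Among the compounds with values here, every measured step changes the aryl group on the ring nitrogen; none touches the basic side chain on the saturated carbon, so no measured step bears directly on this change. In the absence of a relevant step, the expectation for this assay is a change of a 1.0-fold higher number from compound 3 to compound 4 (0.02 log units; within the scatter), which is not beyond the scatter. Compound 4 is therefore estimated at 2500 nM, within a range from 900 nM to 7000 nM.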

Compound 4, half-maximal inhibitory concentration: 1360 nM
Estimate against measurement, compound 4: 1.8-fold (0.26 log units) above; the measured number falls inside the stated range.
By their numbers in this assay, from the lowest: compounds 4, 3 and 1 (each within the scatter of the next, the first and the last beyond it). At a limit, above all of these: compound 2.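

In this assay, within the data shown here, the only measured change at the saturated chain carbon bound to an aromatic carbon gives a 1.8-fold lower number from compound 3 to compound 4 (0.25 log units; within the scatter), so compound 3 and compound 4 cannot be ordered. With the 3-(trifluoromethyl)phenyl group held fixed, this place accepts one five-membered non-aromatic ring with 1 hetero atom in place of one six-membered non-aromatic ring with 2 hetero atoms, and the number stays within the scatter; the 4-methylpiperazin-1-yl group is therefore not needed here to keep a value of this size. No measurement shown accounts for this step.

Still open, from the compounds shown here alone, is how this place responds to groups further from these two, such as morpholin-4-yl, an open-chain dimethylamino group, or a longer chain between the aromatic carbon and the ring nitrogen of the amine. Also open, going by these compounds, is whether pyrrolidin-1-yl reads the same way when the aryl group on the ring nitrogen is 3-chloro-4-fluorophenyl or 3,4-difluorophenyl rather than 3-(trifluoromethyl)phenyl.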